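Shortening the carbonyl substituent in a piperidine series

The source may hold more compounds than are shown below. What is called first, only, known or untested is meant among the compounds shown, and "the series" means these compounds.

Compound 1 `Cc1nc(S(C)(=O)=O)ccc1Oc1ncnc(OC2CCN(C(=O)OC(C)(C)C(F)(F)F)CC2)c1F` is the reference of this set. In a functional assay on isolated protein for inhibition of Glucose-dependent insulinotropic receptor (Rattus norvegicus), read by HTRF and cAMP accumulation (a higher number here means that more compound is needed for the effect, a lower number that less compound is needed), compound 1 gives 47.2 nM, the lowest of the three numbers: compound 2 `Cc1nc(S(C)(=O)=O)ccc1Oc1ncnc(OC2CCN(C(=O)OC(C)(C)CF)CC2)c1F` gives 138 nM and compound 3 `Cc1nc(S(C)(=O)=O)ccc1Oc1ncnc(OC2CCN(C(=O)SC3CC3)CC2)c1F` gives 126 nM. Compound 4 `Cc1nc(S(C)(=O)=O)ccc1Oc1ncnc(OC2CCN(C(=O)C(F)(F)F)CC2)c1F` differs from compound 1 in one place: trifluoromethyl in place of 1-methyl-1-(trifluoromethyl)ethoxy on a carbonyl carbon. Within the data shown here, two measured steps bear on this change, both altering the group on the same carbonyl carbon, and both raised the number modestly: a 2.9-fold higher number from compound 1 to compound 2 (0.47 log units; beyond the scatter) and a 2.7-fold higher number from compound 1 to compound 3 (0.43 log units; beyond the scatter). Compound 4 removes the whole (1-methyl-1-(trifluoromethyl)ethoxy)carbonyl in favour of (trifluoromethyl)carbonyl, a larger cut than either. A higher number is therefore expected, a 3.4-fold higher number from compound 1 to compound 4 (0.53 log units; beyond the scatter). Compound 4 is estimated at 160 nM, within 60 nM to 450 nM.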

Compound 4, half-maximal effective concentration: 880 nM
Compound 4: the middle estimate sits 5.5-fold (0.74 log units) below what was measured, outside the stated range (above it).
By their numbers in this assay, from the lowest: compound 1; then compounds 3 and 2 (each within the scatter of the next); then compound 4.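

In this assay, the position tolerates replacement of the 1-methyl-1-(trifluoromethyl)ethoxy group far less well than compounds 2 and 3 suggested, as trifluoromethyl on the carbonyl carbon gives a large rise (a 19-fold higher number from compound 1 to compound 4 (1.27 log units; beyond the scatter)). Compound 4 also stands clearly apart from the two earlier analogues (a 7.0-fold higher number from compound 3 to compound 4 (0.84 log units; beyond the scatter); a 6.4-fold higher number from compound 2 to compound 4 (0.80 log units; beyond the scatter)), each of which keeps an oxygen or sulfur on that carbonyl carbon. Nothing available here explains this rise.

Going by these compounds, whether it follows from losing that oxygen or sulfur or from the smaller group remains open. A tert-butyl or methoxy group on the same carbonyl carbon would help separate the two.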